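Extending the ketone side chain of compound 3

The source may hold more compounds than are shown below. What is called first, only, known or untested is meant among the compounds shown, and "the series" means these compounds.

The compounds here share one core, a substituted phenol carrying a ketone and a four-carbon ether linker to a second benzoic-acid ring. Compound 1 `Cc1c(OCCCCOc2ccc(C(=O)O)cc2Cl)ccc(C(=O)CC(C)C)c1O` and compound 2 `Cc1c(OCCCCOc2cccc(C(=O)O)c2)ccc(C(=O)CC(C)C)c1O` both carry an isobutylcarbonyl group on that core and differ only in the acid ring. In an assay on HEK293 cells for positive allosteric modulation of metabotropic glutamate receptor 3 (Rattus norvegicus), read by thallium flux, with a stated time of 2.5 min (on this read-out higher numbers stand for an effect only at larger amounts of compound and lower numbers for an effect already at smaller amounts), compound 1 gives 1140 nM, and in this assay compound 2 gives 1430 nM; the step of a 1.3-fold higher number from compound 1 to compound 2 (0.10 log units; within the scatter) shows that this change in the acid ring hardly matters.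

Compound 3 `CC(=O)c1ccc(OCCCCOc2ccc(F)c(C(=O)O)c2)c(C)c1O` carries an acetyl group in place of the isobutylcarbonyl and a fluorinated acid ring. For compound 3 the entry in this assay reads "not determined" (no result reported), so it stands nowhere on the scale of the measured values. Compound 4 `Cc1c(OCCCCOc2ccc(F)c(C(=O)O)c2)ccc(C(=O)CC(C)C)c1O` differs from it by isopropyl in place of hydrogen on a saturated chain carbon bound to a carbonyl carbon.

Among the compounds with values here, no measured step touches this change. What the data do show is that both isobutylcarbonyl compounds, compound 1 and compound 2, sit close together, and the acid-ring variation between them is within the scatter. Compound 4 carries that same isobutylcarbonyl group, and its acid ring is a further variation of the kind that did not move the numbers. Compound 4 is therefore expected to land near those two, estimated at 1300 nM with a range from 400 nM to 4500 nM.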

Compound 4, half-maximal effective concentration: 920 nM
Compound 4: middle estimate off by 1.4-fold (0.15 log units), on the high side; low and high end bracket the measured number.
By their numbers in this assay, from the lowest: compounds 4, 1 and 2 (each within the scatter of the next).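

Compound 4 gives the isobutylcarbonyl compounds a third acid ring. In this assay, fluoro in place of hydrogen on an aromatic carbon gives a 1.6-fold lower number from compound 2 to compound 4 (0.19 log units; within the scatter), and exchanging the 4-carboxy-2-chlorophenyl for 3-carboxy-4-fluorophenyl gives a 1.2-fold lower number from compound 1 to compound 4 (0.09 log units; within the scatter), so with the isobutylcarbonyl group held constant, neither change separates these compounds beyond the usual variation between repeated measurements. Within the data shown here, the step from acetyl to isobutylcarbonyl, the one change that links compound 3 to compound 4, cannot be read, as compound 3 has no number, and no data are at hand that could account for the small differences among the other compounds.

From the compounds shown here alone, what remains open is how far the number depends on the ketone side chain, for instance whether a longer chain, a cyclopropyl group or a chain ending in an amine would stay in the same range as the isobutylcarbonyl compounds. Also open, going by these compounds, is whether the carboxylic acid itself can be exchanged, for example for a primary amide or a tetrazole, without moving the number in this assay.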